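Mirror-image fluorocyclopropyl amide on the shared bicyclic core

A few compounds are considered here, and "the series" means these few. Any claim that something is new, unique, unknown or untested is made for them only; others in the source may bear on it.

Measured compounds:
compound 1 `O=C(C1CCC1)N1CC2CC(C1)N2` 240 nM
compound 2 `O=C([C@@H]1C[C@@H]1F)N1CC2CC(C1)N2` 55 nM
compound 3 `O=C([C@H]1C[C@@H]1F)N1CC2CC(C1)N2` 490 nM

In an assay on CHO cells for displacement of a labelled ligand from Neuronal acetylcholine receptor; alpha3/alpha6/beta2/beta3 (Homo sapiens), read by scintillation counting (on this read-out lower numbers stand for stronger inhibition and higher numbers for weaker inhibition), compound 3 gives the highest of the three numbers: compound 1 is the nearest, with a 2.0-fold higher number from compound 1 to compound 3 (0.31 log units; beyond the scatter), and compound 2 is the furthest, with an 8.9-fold higher number from compound 2 to compound 3 (0.95 log units; beyond the scatter). For the measured compounds named here, the only evidence attached to that last step is the fact that one of compounds 2 and 3 is drawn with a defined configuration and the other without, at the place where they differ.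

Compound 4 `O=C([C@@H]1C[C@H]1F)N1CC2CC(C1)N2` has the same atoms and bonds as compound 3; the difference is the two compounds have the same atoms and bonds; at least one stereo element is drawn with a configuration in one of them and without one in the other: 2 of 4 stereo elements differ; a stereocentre at a saturated ring carbon is drawn R in compound 3 and S in compound 4; a stereocentre at a saturated ring carbon is drawn S in compound 3 and R in compound 4. Going by the values given here, no measured step matches this change. The closest guide is the step from compound 2 to compound 3, an 8.9-fold higher number from compound 2 to compound 3 (0.95 log units; beyond the scatter), which shows that a single change of drawn configuration on the saturated ring carbons moves this read-out well beyond the scatter. The two steps from compound 1, a 4.4-fold lower number from compound 1 to compound 2 (0.64 log units; beyond the scatter) and a 2.0-fold higher number from compound 1 to compound 3 (0.31 log units; beyond the scatter), set the span within which the fluorinated cyclopropyl amides have so far fallen. Because an 8.9-fold higher number from compound 2 to compound 3 (0.95 log units; beyond the scatter) was large, a change at both centres is expected to move the number again, but its direction cannot be read from these three compounds. Compound 4 is therefore estimated near the middle of the observed span, at 200 nM, between 40 nM and 1000 nM, which would mean a step of a 2.5-fold lower number from compound 3 to compound 4 (0.39 log units; beyond the scatter).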

Compound 4, inhibition constant: 43 nM
The estimate for compound 4 lay 4.7-fold (0.67 log units) above the measured number; the range from low to high includes it.
By their numbers in this assay, from the lowest: compounds 4 and 2 (each within the scatter of the next); then compound 1; then compound 3.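

In this assay, the change at both saturated ring carbons gives an 11-fold lower number from compound 3 to compound 4 (1.06 log units; beyond the scatter), a large step that the single-centre step to compound 3 had only hinted at, while the single-centre change a 1.3-fold lower number from compound 2 to compound 4 (0.11 log units; within the scatter) stays within the scatter. The two single-centre changes on the fluorocyclopropyl ring therefore do not behave alike: one moves the number well beyond the scatter and the other leaves it within the scatter, so the drawn configuration matters at one centre far more than at the other among these compounds. The 2-fluorocyclopropyl group in place of cyclobutyl now also gives a 5.6-fold lower number from compound 1 to compound 4 (0.75 log units; beyond the scatter), in the same direction as the step to compound 2, with compound 3 going against that direction, so the replacement alone does not fix the outcome, and the only evidence on the large step is its configuration: the fact that one of compounds 3 and 4 is drawn with a defined configuration and the other without, at the place where they differ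

The compounds shown leave open how the remaining combination of the two centres would read. They also leave open whether a plain cyclopropyl, a 2,2-difluorocyclopropyl or a 2-methylcyclopropyl amide on the shared core would fall with compound 2 and compound 4 or with compound 3.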